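A few compounds are considered here, and "the series" means these few. Any claim that something is new, unique, unknown or untested is made for them only; others in the source may bear on it.

Measured compounds:
- compound 1, `Cc1cn([C@@H]2O[C@H](CO[Si](C)(C)C(C)(C)C)[C@@]3(OS(=O)(=O)C=C3NCC(N)=O)[C@H]2O[Si](C)(C)C(C)(C)C)c(=O)n(C)c1=O`: 16000 nM
- compound 2, `Cc1cn([C@@H]2O[C@H](CO[Si](C)(C)C(C)(C)C)[C@@]3(OS(=O)(=O)C=C3NCC(=O)C(=O)N3CCC3)[C@H]2O[Si](C)(C)C(C)(C)C)c(=O)n(C)c1=O`: 65000 nM
- compound 3, `Cc1cn([C@@H]2O[C@H](CO[Si](C)(C)C(C)(C)C)[C@@]3(OS(=O)(=O)C=C3NC(N)=O)[C@H]2O[Si](C)(C)C(C)(C)C)c(=O)n(C)c1=O`: 16000 nM

All three were tested in a functional assay on HEL cells (Homo sapiens) for cytotoxicity, read by microscopy; on this read-out higher numbers stand for lower toxicity in this test and lower numbers for higher toxicity in this test. On these numbers compound 2 stands highest, meaning it was the least toxic of the three; its nearest neighbour is compound 1, and the gap a 4.1-fold higher number from compound 1 to compound 2 (0.61 log units; beyond the scatter) is not explained by repeat-measurement noise alone, nor is a 4.1-fold lower number from compound 2 to compound 3 (0.61 log units; beyond the scatter). Compound 1 and compound 3 give the same reading.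

Compound 4, `COC(=O)C(=O)CNC1=CS(=O)(=O)O[C@@]12[C@@H](CO[Si](C)(C)C(C)(C)C)O[C@@H](n1cc(C)c(=O)n(C)c1=O)[C@@H]2O[Si](C)(C)C(C)(C)C`, has not yet been measured. It differs from compound 2 in one place: methoxy in place of azetidin-1-yl on a carbonyl carbon. The step that bears most directly on this change is the one at the same carbonyl carbon, a 4.1-fold higher number from compound 1 to compound 2 (0.61 log units; beyond the scatter), where the azetidin-1-yl-bearing group in place of amino raised the number modestly. Methoxy is neither of those two groups, so the new reading is expected to fall somewhere between the value of compound 2 and that of compound 1, most likely a little below compound 2. The expected step of a 1.6-fold lower number from compound 2 to compound 4 (0.21 log units; within the scatter) is therefore small and downward, or none beyond the scatter. Compound 4 is estimated at 40000 nM, with a range from 13000 nM to 130000 nM.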

Compound 4, minimum cytotoxic concentration: > 400000 nM
Compound 4: no number, only a limit; the forecaster's own chance of this, stated with the estimate: 10%; at least 10-fold (1.00 log units) between middle value and limit.
By their numbers in this assay, from the lowest: compounds 1 and 3 (each within the scatter of the next); then compound 2. At a limit, above all of these: compound 4.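

In this assay compound 4 gives no number, only a limit, so the steps to it mark minimum sizes and not exact gaps: the limit of > 400000 nM in this assay, at which 1 of the 4 values shown sits. Even so, the group on this carbonyl carbon turns out to matter more than the earlier compounds showed, since replacing azetidin-1-yl with methoxy gives an at least 6.1-fold higher number from compound 2 to compound 4 (0.78 log units; beyond the scatter), a change in the same direction as the earlier step of a 4.1-fold higher number from compound 1 to compound 2 (0.61 log units; beyond the scatter). Methoxycarbonyl in place of amino on a carbonyl carbon gives an at least 25-fold higher number from compound 1 to compound 4 (1.39 log units; beyond the scatter), and ((methoxycarbonyl)carbonyl)methyl in place of carbamoyl on the amine nitrogen gives an at least 25-fold higher number from compound 3 to compound 4 (1.39 log units; beyond the scatter), so this one end group carries the series well past the narrow span of the three earlier readings.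

The compounds shown leave open how far the true reading of compound 4 lies past its limit, and whether the methoxy group is special or an ethoxy group, a benzyloxy group or a carboxylic acid at the same carbonyl carbon would read the same way. They also give no measurement that explains why this exchange lowers toxicity in this assay.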